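Swapping iodo for acetamido on a capsaicin-like amide

A few compounds are considered here, and "the series" means these few. Any claim that something is new, unique, unknown or untested is made for them only; others in the source may bear on it.

Two compounds have been measured in an assay on HEK293 cells for inhibition of transient receptor potential cation channel subfamily V member 1 (Homo sapiens); on this read-out higher numbers stand for weaker inhibition and lower numbers for stronger inhibition:

Compound 1, `CCCCCCCCC(=O)NCc1ccc(O)c(OC)c1I`, gives 3380 nM.
Compound 2, `CCCCCCCCC(=O)NCc1cc(CC)c(O)c(OC)c1`, gives 355 nM.

Compound 1 stands at the highest of the two numbers, meaning it is the weaker inhibitor of the pair. Compound 2, which differs from it in more than one place, sits at a clearly lower number, a gap well beyond the scatter of repeat measurements. Since the two differ at several positions at once, nothing can be said about which single change is responsible.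

Compound 3, `CCCCCCCCC(=O)NCc1ccc(O)c(OC)c1NC(C)=O`, has not been measured. It is made from compound 1 by one change: acetamido in place of iodo on an aromatic carbon. Within the data shown here, no measured pair in this set shows what this kind of exchange does, so the expectation rests on compound 1 alone. The estimated step from compound 1 to compound 3 in this assay is a 2.4-fold higher number from compound 1 to compound 3 (0.37 log units; beyond the scatter), a modest weakening that may reach beyond the scatter. Compound 3 is thus expected to give about 8000 nM, within a range from 2000 nM to 40000 nM.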

Compound 3, half-maximal inhibitory concentration: 9540 nM
Beside the measured number, compound 3's estimate is 1.2-fold (0.08 log units) below it, and the stated range covers the measured number.
By their numbers in this assay, from the lowest: compound 2; then compound 1; then compound 3.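

Among these compounds, this is the first comparison in the set that differs in only one place: on this aromatic carbon, ortho to a large group and ortho to a methoxy group, acetamido in place of iodo gives a 2.8-fold higher number from compound 1 to compound 3 (0.45 log units; beyond the scatter) in this assay. The position therefore responds to what it carries, and exchanging a single iodine atom for a group of 4 heavy atoms with a hydrogen-bond donor and a hydrogen-bond acceptor leaves a weaker inhibitor, although the step is only modest. Nothing measured here explains the shift, so it remains unclear whether the size of the group, its added donor and acceptor, or the loss of iodine matters most.

A plain amine or a carboxylic acid on this same carbon would show whether the weakening is specific to acetamido or extends to other nitrogen- or oxygen-bearing groups. Compound 2 differs from both compound 1 and compound 3 in more than one place, so it cannot settle this question.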